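This account rests on a few compounds, and the source may have more. Where it says the series, first, only, none or still open, it means among the compounds named here.

Measured compounds:
compound 1, `CCCCCCCCC(=O)N1c2ccccc2CCC1C(=O)Nc1ccccc1C(F)(F)F`, 4320 nM in a functional assay on PC-3 cells (Homo sapiens) for cytotoxicity, read by sulforhodamine B assay, with a stated time of 72 h; a higher number here means a weaker inhibitor of growth, a lower number a stronger inhibitor of growth
compound 2, `O=C(Nc1ccccc1C(F)(F)F)C1CCc2ccccc2N1`, 53300 nM in this assay

Within the data shown here, compound 2 stands highest of the two numbers in this assay; its nearest neighbour is compound 1, and the one measured step runs a 12-fold higher number from compound 1 to compound 2 (1.09 log units; beyond the scatter), where hydrogen replaced octylcarbonyl on the ring nitrogen. Compound 3, `O=C(Nc1ccccc1C(F)(F)F)C1CCc2ccccc2N1C(=O)c1cccc(Cl)c1`, is reached by the change ((3-chlorophenyl)carbonyl in place of hydrogen on a nitrogen on an aromatic ring in a ring). That step bears directly on the measured one, since both alter the same nitrogen. Compound 3 is therefore expected to give a lower number, a step of a 6.7-fold lower number from compound 2 to compound 3 (0.82 log units; beyond the scatter). The estimate for compound 3 in this assay is 8000 nM, with a range from 2000 nM to 30000 nM.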

Compound 3, concentration for 50% growth inhibition: 729 nM
Compound 3: the middle estimate sits 11-fold (1.04 log units) above what was measured; the whole stated range lies above it.
By their numbers in this assay, from the lowest: compound 3; then compound 1; then compound 2.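

In this assay, the ring nitrogen accepts an aromatic acyl group as well as a long-chain one: (3-chlorophenyl)carbonyl in place of hydrogen gives a 73-fold lower number from compound 2 to compound 3 (1.86 log units; beyond the scatter) and so restores growth inhibition beyond what octylcarbonyl achieved. The group on the carbonyl therefore matters, not just the presence of an acyl group, with a 5.9-fold lower number from compound 1 to compound 3 (0.77 log units; beyond the scatter) on exchanging octyl for 3-chlorophenyl. No evidence here explains this difference. As far as these compounds go, whether benzoyl without the chlorine, or a shorter acyl chain, would serve as well remains open, as does whether this order holds in other cell lines.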